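Working notes on compounds 1 to 4

The source may hold more compounds than are shown below. What is called first, only, known or untested is meant among the compounds shown, and "the series" means these compounds.

Measured compounds:
Compound 1 `O=c1cc(Cn2cc(CCCCl)nn2)c2ccc(O)cc2o1` gives 75800 nM in a functional assay on CFPAC-1 cells (Homo sapiens) for inhibition, read by MTT assay, with a stated time of 72 h; on this read-out higher numbers stand for weaker inhibition and lower numbers for stronger inhibition.
Compound 2 `CC(C)(C)c1cn(Cc2cc(=O)oc3cc(O)ccc23)nn1` sits at a limit of this assay, > 100000 nM.
Compound 3 `O=c1cc(Cn2cc(CCc3ccccc3)nn2)c2ccc(O)cc2o1` sits at a limit of this assay, > 100000 nM.

Compound 3 therefore stands only at a limit, not at a number, and it shares that limit with one other value shown (the limit of > 100000 nM in this assay, at which 2 of the 3 values shown sit). Compound 4 `O=c1cc(Cn2cc(-c3ccc(Br)cc3)nn2)c2ccc(O)cc2o1` differs from compound 3 by 4-bromophenyl in place of phenethyl on an aromatic carbon. The measured steps give little to read for this change: an at least 1.3-fold higher number from compound 1 to compound 3 (0.12 log units; that floor lies within the scatter), an at least 1.3-fold higher number from compound 1 to compound 2 (0.12 log units; that floor lies within the scatter), and a step that the two limits leave unreadable from compound 2 to compound 3. None of them resolves a change at the carbon of the five-membered aromatic ring with 3 nitrogen into a readable size, and none shows a direction beyond the scatter. Compound 4 is therefore expected to stay near the limit, with a step of an at least 1.1-fold lower number from compound 3 to compound 4 (0.04 log units; that floor lies within the scatter) that cannot be called a change beyond the scatter. The estimate for compound 4 is 90000 nM, with a range from 30000 nM to 300000 nM, and it is quite likely that this assay again reports only a limit for compound 4.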

Compound 4, half-maximal inhibitory concentration: 52900 nM
Compound 4: middle estimate off by 1.7-fold (0.23 log units), on the high side, within the range that was stated.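

In this assay compound 4, with 4-bromophenyl on the aromatic carbon of the five-membered aromatic ring with 3 nitrogen, gives a number, so this position now has two measured numbers while the other values remain limits: the limit of > 100000 nM in this assay, at which 2 of the 4 values shown sit.

Against the two limit compounds, the change reads as an at least 1.8-fold lower number from compound 3 to compound 4 (0.27 log units; that floor lies within the scatter) and as an at least 1.8-fold lower number from compound 2 to compound 4 (0.27 log units; that floor lies within the scatter), so neither step shows a change beyond the scatter. Against the other compound with a number, it reads as a 1.4-fold lower number from compound 1 to compound 4 (0.16 log units; within the scatter), so 4-bromophenyl and 3-chloropropyl cannot be told apart at this position.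

The compounds shown do not separate the effect of the bromine from that of the larger change from phenethyl to 4-bromophenyl. As far as these compounds go, how an amine or a carboxylic acid in place of the bromine would read in this assay remains open.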